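The source may report more compounds than this note shows. Statements on the series, on what has been measured and on what is new or still open speak of the compounds shown alone.

The set is read in an ADME assay on HepG2 cells (Homo sapiens) for cytotoxicity, read by CellTiter-Glo and resazurin assay, with a stated time of 72 h; on this read-out higher numbers stand for an effect only at larger amounts of compound and lower numbers for an effect already at smaller amounts. Compound 1 `CC(C)N(Cc1cccc(OCCCCCC(=O)O)c1)C(=O)c1ccc(-c2cccc(C(F)(F)F)c2)cc1` carries a trifluoromethyl group on its outer ring and a free carboxylic acid at the end of its chain. In this assay compound 1 reaches only the limit of the measurement, > 26000 nM. Compound 2 `CC(C)N(Cc1cccc(OCCCCCC(=O)O)c1)C(=O)c1ccc(-c2cccc(Br)c2)cc1` differs from compound 1 by bromo in place of trifluoromethyl on an aromatic carbon. In this assay compound 2 likewise stops at the limit, > 26000 nM. Compound 3 `CCOC(=O)CCCCCOc1cccc(CN(C(=O)c2ccc(-c3cccc(C(F)(F)F)c3)cc2)C(C)C)c1` differs from compound 1 by ethyl in place of hydrogen on an oxygen next to a carbonyl group, which is also how the cores of compound 3 and compound 1 differ. In this assay compound 3 gives only the limit, > 26000 nM.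

The step that the two limits leave unreadable from compound 1 to compound 2 thus has no readable size, and the same holds for a step that the two limits leave unreadable from compound 1 to compound 3; both rest on (the limit of > 26000 nM in this assay, at which 3 of the 3 values shown sit).

Compound 4 `CCOC(=O)CCCCCOc1cccc(CN(C(=O)c2ccc(-c3cccc(Br)c3)cc2)C(C)C)c1` has not yet been measured in this assay. It differs from compound 3 by bromo in place of trifluoromethyl on an aromatic carbon, the same change that separates compound 1 from compound 2, at a place described in the same words, but on the core of compound 3 rather than that of compound 1. The step expected from compound 3 to compound 4 is a step that the limit leaves unreadable from compound 3 to compound 4, set beside a step that the two limits leave unreadable from compound 1 to compound 2, and it rests on compound 3 sitting at > 26000 nM and on (the limit of > 26000 nM in this assay, at which 3 of the 3 values shown sit). For compound 4 the estimated value in this assay is 40000 nM, with an expected range from 20000 nM to 100000 nM.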

Compound 4, half-maximal effective concentration: > 26000 nM
Compound 4 ended at the assay's limit; the forecaster's own chance of this, stated with the estimate: 90%; the middle value lies beyond the limit too.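

No new step can be read for compound 2, compound 3 or compound 4, as each of these pairs ends in two limits and not in numbers: the limit of > 26000 nM in this assay, at which 4 of the 4 values shown sit.

In this assay the compounds shown leave open whether bromo in place of trifluoromethyl, or ethyl in place of the acid hydrogen, makes any difference, and at what concentration any of them would show an effect.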